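The source may report more compounds than this note shows. Statements on the series, on what has been measured and on what is new or still open speak of the compounds shown alone.

Measured in a functional assay on IMR-32 cells (Homo sapiens) for antiproliferative activity, with a stated time of 72 h; on this read-out lower numbers stand for stronger inhibition and higher numbers for weaker inhibition:
- Compound 1 `O=C(CCN(Cc1ccc(C(=O)NO)cc1)C(=O)c1ccccc1)NCc1ccccc1`: 2360 nM
- Compound 2 `COc1cc(OC)cc(C(=O)N(CCC(=O)NCc2ccccc2)Cc2ccc(C(=O)NO)cc2)c1`: 6040 nM
- Compound 3 `Cc1ccc(NC(=O)CCN(Cc2ccc(C(=O)NO)cc2)C(=O)c2ccccc2)cc1`: 550 nM

Of these three, compound 3 has the lowest number, at 550 nM. The nearest neighbour is compound 1 at 2360 nM, and furthest away lies compound 2 at 6040 nM.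

Compound 4 `Cc1ccc(NC(=O)CCN(Cc2ccc(C(=O)NO)cc2)C(=O)c2ccc(N(C)C)cc2)cc1` keeps everything in compound 3 except for one change: dimethylamino in place of hydrogen on an aromatic carbon, para to a large group, which turns benzoyl into (4-(dimethylamino)phenyl)carbonyl (dimethylamino in place of hydrogen on an aromatic carbon).

Going by the values given here, the closest precedent is a 2.6-fold higher number from compound 1 to compound 2 (0.41 log units; beyond the scatter), where 3,5-dimethoxyphenyl replaced phenyl on a carbonyl carbon. That is the same phenyl that changes here, and the step was modest. The other measured step, a 4.3-fold lower number from compound 1 to compound 3 (0.63 log units; beyond the scatter), was made at a different place, on an amide-type nitrogen, so it bears on this change only weakly. Among the compounds with values here, no measurement shows whether the first step carries over to compound 3, and no dimethylamino compound has been measured yet.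

Within the data shown here, a small move toward a higher number therefore seems likely, no larger than the precedent and perhaps within the scatter. The expected step is a 1.5-fold higher number from compound 3 to compound 4 (0.16 log units; within the scatter). Compound 4 is estimated at 800 nM, with an expected range from 300 nM to 2000 nM.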

Compound 4, half-maximal inhibitory concentration: 300 nM
The estimate for compound 4 lay 2.7-fold (0.43 log units) above the measured number, and the stated range covers the measured number.
By their numbers in this assay, from the lowest: compounds 4 and 3 (each within the scatter of the next); then compound 1; then compound 2.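

In this assay, dimethylamino on the aromatic carbon para to a large group, on the phenyl of the benzoyl, gives a 1.8-fold lower number from compound 3 to compound 4 (0.26 log units; within the scatter), so compound 3 and compound 4 cannot be told apart. Going by these compounds alone, this shows that the phenyl on the carbonyl carbon can carry this group without a change beyond the scatter, whereas the only earlier change on that phenyl, to 3,5-dimethoxyphenyl, gave a 2.6-fold higher number from compound 1 to compound 2 (0.41 log units; beyond the scatter); that step, however, was made with the benzyl group on the amide-type nitrogen, while the new one was made with 4-methylphenyl there, so the two steps differ in more than the group that enters. No measured evidence accounts for the size of either step.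

The compounds shown leave open whether 4-(dimethylamino)phenyl would give a similar result with the benzyl group of compound 1 in place of 4-methylphenyl, and whether 3,5-dimethoxyphenyl would repeat its step alongside 4-methylphenyl. They also leave open how a primary amine, a morpholine or a carboxylic acid would read on the same aromatic carbon.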